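Bromine in Place of Thiophene on a Fused Core

This account rests on a few compounds, and the source may have more. Where it says the series, first, only, none or still open, it means among the compounds named here.

Measured compounds:
- compound 1, `Cc1cc(I)cn2c(CSCCc3ccccc3)cnc12`: in an ADME assay on HEL cells (Homo sapiens) for cytotoxicity, with a stated time of 3 days (a higher number here means that more compound is tolerated, a lower number that less compound is tolerated), compound 1 gives >= 0.8 ug/mL, which is a limit of the assay.
- compound 2, `Cc1cc(-c2cccs2)cn2c(CSCCc3ccccc3)cnc12`: in this assay compound 2 gives 20 ug/mL.

Compound 2 therefore stands as the only number shown here; the other result is a limit, (the limit of >= 0.8 ug/mL in this assay, at which 1 of the 2 values shown sits), so the change a step that the limit leaves unreadable from compound 1 to compound 2 cannot be sized. Compound 3, `Cc1cc(Br)cn2c(CSCCc3ccccc3)cnc12`, differs from compound 2 by bromo in place of thiophen-2-yl on an aromatic carbon. No readable measured step bears on this change, so the expectation for compound 3 rests on compound 2 alone. Compound 3 is expected to show a 1.3-fold lower number from compound 2 to compound 3 (0.12 log units; within the scatter), which is no step beyond the scatter. Compound 3 is thus estimated at 15 ug/mL, between 3 ug/mL and 60 ug/mL.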

Compound 3, minimum cytotoxic concentration: >= 2 ug/mL
Compound 3 ended at the assay's limit; the forecaster's own chance of this, stated with the estimate: 30%; the middle value does not contradict the limit.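

No new step can be read, since the result for compound 3 in this assay is a limit of the assay, and it cannot be sized against compound 1 or compound 2. Still open, on these data alone, is how far compound 1 and compound 3 truly stand from compound 2.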